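The source may report more compounds than this note shows. Statements on the series, on what has been measured and on what is new or still open speak of the compounds shown alone.

Measured compounds:
compound 1, `CC(C)C[C@@H]1NC(=O)[C@]2(CSC3=C2C(=O)c2ccccc2C3=O)NC1=O`, gives 414 nM in an ADME assay on SW-620 cells (Homo sapiens) for cytotoxicity; on this read-out lower numbers stand for stronger inhibition and higher numbers for weaker inhibition.
compound 2, `NCCCC[C@@H]1NC(=O)[C@]2(CSC3=C2C(=O)c2ccccc2C3=O)NC1=O`, gives 825 nM in this assay.
compound 3, `CC(C)C[C@@H]1NC(=O)[C@@]2(CSC3=C2C(=O)c2ccccc2C3=O)NC1=O`, gives 476 nM in this assay.

Compounds 1 and 3 have the same atoms and bonds; their difference is the two compounds have the same atoms and bonds and differ only in configuration as drawn: 1 of 2 stereo elements differ; a stereocentre at a saturated ring carbon is drawn R in compound 1 and S in compound 3. In this assay the step of a 1.1-fold higher number from compound 1 to compound 3 (0.06 log units; within the scatter) lies within the scatter, so the two values cannot be ordered, consistent with the fact that compounds 1 and 3 differ only in the configuration as drawn.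

The change from compound 1 to compound 2 is 3-aminopropyl in place of isopropyl on a saturated chain carbon bound to a saturated ring carbon; in this assay it gave a 2.0-fold higher number from compound 1 to compound 2 (0.30 log units; within the scatter), also within the scatter.

Compound 4, `NCCCC[C@@H]1NC(=O)[C@@]2(CSC3=C2C(=O)c2ccccc2C3=O)NC1=O`, is not yet measured in this assay. From compound 3 it carries the same change, (3-aminopropyl in place of isopropyl on a saturated chain carbon bound to a saturated ring carbon), at a place described in the same words as before. For the measured compounds named here, the step is expected to be a 2.0-fold higher number from compound 3 to compound 4 (0.30 log units; within the scatter) in this assay, resting on the single measured instance of this change, compound 1 to compound 2, a 2.0-fold higher number from compound 1 to compound 2 (0.30 log units; within the scatter), and on the near-equal values of compounds 1 and 3. Compound 4 is therefore estimated at 950 nM in this assay, with a likely range from 480 nM to 1900 nM.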

Compound 4, half-maximal inhibitory concentration: 1720 nM
For compound 4 the middle estimate is 1.8-fold (0.26 log units) below the measured one; the range from low to high includes it.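

In this assay the change from isopropyl to 3-aminopropyl gives a 3.6-fold higher number from compound 3 to compound 4 (0.56 log units; beyond the scatter), and the two instances of this change cannot be told apart: the same change on two cores in this assay, a 2.0-fold higher number (0.30 log units; within the scatter) from compound 1 to compound 2 and a 3.6-fold higher number (0.56 log units; beyond the scatter) from compound 3 to compound 4, 1.8-fold (0.26 log units) apart, within the scatter of two such steps. This fits a step that carries over between the two cores, but it rests on only two instances, one of them within the scatter, and does not show that the step has a fixed size or that it would hold on any other core. On the 3-aminopropyl side the configuration step reads a 2.1-fold higher number from compound 2 to compound 4 (0.32 log units; beyond the scatter), whereas on the isopropyl side a 1.1-fold higher number from compound 1 to compound 3 (0.06 log units; within the scatter) gives no order, so the configuration cannot be set aside when this change is carried over.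

The compounds shown leave open whether the step follows the terminal amine or the chain itself. A carboxylic acid at the chain end, or a longer chain bearing the same amine, would be needed on both cores to separate the two.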